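Methyl-to-hydrogen change on a phenol oxygen, tolerance readout

This account rests on a few compounds, and the source may have more. Where it says the series, first, only, none or still open, it means among the compounds named here.

Compound 1 `COc1cc(-c2nn(-c3cccc(NC(=O)Nc4cc(C(F)(F)F)cc(C(F)(F)F)c4)c3)cc2-c2ccncc2)ccc1Cl` and compound 2 `O=C(Nc1cccc(-n2cc(-c3ccncc3)c(-c3ccc(Cl)c(O)c3)n2)c1)Nc1cc(C(F)(F)F)cc(C(F)(F)F)c1` differ only by hydrogen in place of methyl on an oxygen on an aromatic ring. In a functional assay on Malme-3M cells (Homo sapiens) for inhibition, read by sulforhodamine B assay, with a stated time of 48 h (a higher number here means that more compound is tolerated, a lower number that less compound is tolerated), compound 1 gives 7680 nM. Compound 2 gives 23500 nM in this assay. The step is a 3.1-fold higher number from compound 1 to compound 2 (0.49 log units; beyond the scatter), so removing the methyl leaves more compound tolerated in this pair.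

Compound 3 `COc1cc(-c2nn(-c3cccc(NC(=O)Nc4ccc(Cl)c(C(F)(F)F)c4)c3)cc2-c2ccncc2)ccc1Cl` carries a different urea partner; the difference between the two cores is not broken down here. For compound 3 this assay returns only a limit, > 32500 nM, and no number. This is the limit of > 32500 nM in this assay, at which 1 of the 3 values shown sits.

Compound 4 `O=C(Nc1cccc(-n2cc(-c3ccncc3)c(-c3ccc(Cl)c(O)c3)n2)c1)Nc1ccc(Cl)c(C(F)(F)F)c1` stands to compound 3 as compound 2 stands to compound 1: hydrogen in place of methyl on an oxygen on an aromatic ring, the same change at the same place. Compound 4 is not yet measured in this assay. The expected step is a step that the limit leaves unreadable from compound 3 to compound 4, resting on the measured step of a 3.1-fold higher number from compound 1 to compound 2 (0.49 log units; beyond the scatter) being applied to a compound already at the limit. Since compound 3 sits at the limit, compound 4 is expected to return a limit as well rather than a number. The estimate for compound 4 is 70000 nM, with an expected range from 25000 nM to 200000 nM.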

Compound 4, concentration lethal to 50% of the cells: 9580 nM
Compound 4: middle estimate off by 7.3-fold (0.86 log units), on the high side; the measured number lies below the stated range.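

In this assay the methoxy to hydroxy change gives an at least 3.3-fold lower number from compound 3 to compound 4 (0.53 log units; beyond the scatter), so the step seen on the core of compound 1 does not carry over to the core of compound 3, and the two steps run in opposite directions: the same change on two cores in this assay, a 3.1-fold higher number (0.49 log units; beyond the scatter) from compound 1 to compound 2 and an at least 3.3-fold lower number (0.53 log units; beyond the scatter) from compound 3 to compound 4, at least 10-fold (1.01 log units) apart, beyond the scatter of two such steps

Compound 3 has only a limit, > 32500 nM, and not a number, so the direction of its step is readable but the full size is not: the limit of > 32500 nM in this assay, at which 1 of the 4 values shown sits.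

These two pairs show that, in this series, the outcome of the change differs with the urea partner; they give no rule for other urea partners and no explanation of the reversal.

Still open is how the 4-chloro-3-methoxyphenyl to 4-chloro-3-hydroxyphenyl change reads with urea partners beyond the two shown. Also open, going by these compounds, is what an ethyl group or a longer chain on that oxygen would give, or an amine in place of the hydroxy.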